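Fluoro and Chloro Variants of a Dimethoxyphenyl Benzothiazole Core

The source may report more compounds than this note shows. Statements on the series, on what has been measured and on what is new or still open speak of the compounds shown alone.

Compound 1 `COc1ccc(-c2nc3ccccc3s2)cc1OC`: 52700 nM
Compound 2 `COc1ccc(-c2nc3cc(F)ccc3s2)cc1OC`: < 0.1 nM
Compound 3 `COc1ccc(-c2nc3cc(Cl)ccc3s2)cc1OC`: 27900 nM

Three analogues sharing one core were tested in a functional assay on MCF7 cells (Homo sapiens) for antiproliferative activity; on this read-out higher numbers stand for weaker inhibition of growth and lower numbers for stronger inhibition of growth. Compound 1 gives the higher of the two plain numbers, but the gap to compound 3, a 1.9-fold lower number from compound 1 to compound 3 (0.28 log units; within the scatter), lies within the scatter. For compound 2 the value is a limit of this assay and not a number, (the limit of < 0.1 nM in this assay, at which 1 of the 3 values shown sits). Against that limit the step of an at least 520000-fold lower number from compound 1 to compound 2 (5.72 log units; beyond the scatter) is enormous, as is an at least 270000-fold higher number from compound 2 to compound 3 (5.44 log units; beyond the scatter).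

The unmeasured compound 4 `COc1ccc(-c2nc3ccc(F)cc3s2)cc1OC` differs from compound 1 by fluoro in place of hydrogen on an aromatic carbon, the fluoro now standing meta to a fused ring and para to a fused ring. The step bearing most on it is an at least 520000-fold lower number from compound 1 to compound 2 (5.72 log units; beyond the scatter), the same change of hydrogen to fluoro at another carbon, while a 1.9-fold lower number from compound 1 to compound 3 (0.28 log units; within the scatter) shows a halogen at that other carbon leaving the number within the scatter. The expected step of an 11-fold lower number from compound 1 to compound 4 (1.02 log units; beyond the scatter) is therefore downward but highly uncertain. Compound 4 is estimated at 5000 nM, within a range from 10 nM to 60000 nM.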

Compound 4, concentration for 50% growth inhibition: 62 nM
The estimate for compound 4 lay 81-fold (1.91 log units) above the measured number; low and high end bracket the measured number.
By their numbers in this assay, from the lowest: compound 4; then compounds 3 and 1 (each within the scatter of the next). At a limit, below all of these: compound 2.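

Fluoro on this carbon, meta to a fused ring and para to a fused ring, moves the number far beyond the scatter: in this assay the step is an 850-fold lower number from compound 1 to compound 4 (2.93 log units; beyond the scatter). A large downward step on exchanging hydrogen for fluoro is therefore not tied to one carbon of the shared core, as the same exchange at another carbon gave an at least 520000-fold lower number from compound 1 to compound 2 (5.72 log units; beyond the scatter). Among the compounds shown here, compound 4 also gives a plain number, so this is the first fluoro step here with a measured size and not a bound.

On these data alone, compound 2 stands at a limit and not a number, so whether fluoro does more at one carbon than at the other cannot be read: the limit of < 0.1 nM in this assay, at which 1 of the 4 values shown sits. Whether chloro, an amine or a carboxylic acid on this carbon would move the number as fluoro does stays open.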